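Methyl in place of phenyl: notes towards compound 3

This account rests on a few compounds, and the source may have more. Where it says the series, first, only, none or still open, it means among the compounds named here.

In an ADME assay on cells (Homo sapiens) for cytotoxicity, read by sulforhodamine B assay, with a stated time of 48 h (a higher number here means that more compound is needed for the effect, a lower number that less compound is needed), the values so far are these:
- compound 1 `CCN(CC)c1ccc(/C=C2/SC(N(c3ccccc3)c3ccccc3)=NC2=O)cc1` gives > 100000 nM (a limit)
- compound 2 `CN1CCN(c2ccc(/C=C3/SC(N(c4ccccc4)c4ccccc4)=NC3=O)cc2)CC1` gives > 100000 nM (a limit)

Compound 2 has no number, only the limit > 100000 nM as its reading. For the measured compounds named here, the series so far offers the limit of > 100000 nM in this assay, at which 2 of the 2 values shown sit, and nothing more. Compound 3 `CN1CCN(c2ccc(/C=C3/SC(N(C)c4ccccc4)=NC3=O)cc2)CC1` carries methyl in place of phenyl on a nitrogen on an aromatic ring, methyl in place of phenyl on a nitrogen on an aromatic ring. Going by the values given here, the only measured step is a step that the two limits leave unreadable from compound 1 to compound 2, at another place, so it gives no size to carry over. A reading at the same limit in this assay is the likeliest expectation, with only a weak lean towards a lower number. The expected change is an at least 1.2-fold lower number from compound 2 to compound 3 (0.09 log units; that floor lies within the scatter) (an estimate without firm support). For compound 3 the estimated value is 80000 nM (20000 nM to 100000 nM).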

Compound 3, half-maximal effective concentration: > 100000 nM
Compound 3 gave a limit, no number (the forecaster's own chance of this, stated with the estimate: 65%); middle value at least 1.2-fold (0.09 log units) from the limit.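

For the compounds shown here, compound 2 and compound 3 each give only a limit, so no step between them can be read. The compounds shown leave open whether methyl in place of phenyl changes the reading at all, since all stand at one limit: the limit of > 100000 nM in this assay, at which 3 of the 3 values shown sit.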